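A few compounds are considered here, and "the series" means these few. Any claim that something is new, unique, unknown or untested is made for them only; others in the source may bear on it.

Working notes on the series.

Compound 1 `COC(=O)[C@@]1(C)CC[C@@H]2C3=C1CC[C@@H](C)[C@]3(C)C[C@@H]1c3ccccc3N[C@H]21` is the parent of the pair measured so far; in a functional assay on HeLa cells (Homo sapiens) for inhibition, read by sulforhodamine B assay, with a stated time of 48 h (on this read-out lower numbers stand for stronger inhibition of growth and higher numbers for weaker inhibition of growth), compound 1 gives 19000 nM. Compound 2 `COC(=O)[C@@]1(C)CC[C@@H]2C3=C1CC[C@@H](C)[C@]3(C)C[C@@H]1c3cccc(Br)c3N[C@H]21` gives 22000 nM in this assay. For the measured compounds named here, the step of a 1.2-fold higher number from compound 1 to compound 2 (0.06 log units; within the scatter) is the only measured step in the set. Going by the values given here, compound 2 therefore stands at the higher of the two numbers, with compound 1 as its only neighbour, and the gap between them is within the scatter, so no order between the two can be read.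

Compound 3 `COC(=O)[C@@]1(C)CC[C@@H]2C3=C1CC[C@@H](C)[C@]3(C)C[C@@H]1c3cccc(Cl)c3N[C@H]21` is not yet measured. It differs from compound 2 by chloro in place of bromo on an aromatic carbon. Among the compounds with values here, no measured step exchanges one halogen for another; the nearest is a 1.2-fold higher number from compound 1 to compound 2 (0.06 log units; within the scatter), which shows that placing bromo at this aromatic carbon left the number within the scatter of compound 1. For compound 3 the expected step of a 1.1-fold lower number from compound 2 to compound 3 (0.04 log units; within the scatter) is accordingly none beyond the scatter. The estimate for compound 3 in this assay is 20000 nM, with a range from 10000 nM to 40000 nM.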

Compound 3, concentration for 50% growth inhibition: 31000 nM
Beside the measured number, compound 3's estimate is 1.6-fold (0.19 log units) below it; the measured number falls inside the stated range.
By their numbers in this assay, from the lowest: compounds 1, 2 and 3 (each within the scatter of the next).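

In this assay the exchange at this aromatic carbon gives a 1.4-fold higher number from compound 2 to compound 3 (0.15 log units; within the scatter) and the comparison with the parent gives a 1.6-fold higher number from compound 1 to compound 3 (0.21 log units; within the scatter), so the earlier finding for bromo now extends to a second halogen. Chloro and bromo at this carbon, ortho to a fused ring and meta to a fused ring, cannot be told apart from each other or from hydrogen, and no order among the three compounds can be read. No evidence on hand bears on this result.

From the compounds shown here alone, it remains open whether a group of another kind at this carbon, such as an amine, a carboxylic acid or a longer alkyl chain, would move the number beyond the scatter. Also open, going by these compounds, is whether changes elsewhere on the shared core, such as a carboxylic acid in place of the methyl ester, would do so.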